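The source may hold more compounds than are shown below. What is called first, only, known or untested is meant among the compounds shown, and "the series" means these compounds.

In a functional assay on KB cells (Homo sapiens) for inhibition, read by sulforhodamine B assay (a lower number here means a stronger inhibitor of growth, a higher number a weaker inhibitor of growth), compound 1 `c1ccc(-c2ccc(-c3ccc(-c4nc5ccccc5[nH]4)cc3)cc2)cc1` gives 39700 nM and compound 2 `COc1cc(-c2ccc(-c3ccc(-c4nc5cc(C)ccc5[nH]4)cc3)cc2)cc(OC)c1OC` gives 2110 nM. Compound 3 `Oc1cccc2[nH]c(-c3ccc(-c4ccc(-c5ccccc5)cc4)cc3)nc12` gives 4010 nM, within the scatter of the value of compound 2 and clearly lower than that of compound 1. Compound 4 `Oc1cccc2[nH]c(-c3ccc(-c4ccc(-c5ccc(OC(F)(F)F)cc5)cc4)cc3)nc12` differs from it by trifluoromethoxy in place of hydrogen on an aromatic carbon, para to a large group. For the measured compounds named here, the only measured step, a 9.9-fold lower number from compound 1 to compound 3 (1.00 log units; beyond the scatter), is modest and adds hydroxy at a different place, so it bears only weakly on this change. With no firm direction available, little change beyond the scatter is expected. The expected step is a 1.3-fold lower number from compound 3 to compound 4 (0.13 log units; within the scatter). The estimated value for compound 4 is 3000 nM, with an expected range of 900 nM to 10000 nM.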

Compound 4, concentration for 50% growth inhibition: 3310 nM
Estimate against measurement, compound 4: 1.1-fold (0.04 log units) below; the measured number falls inside the stated range.
By their numbers in this assay, from the lowest: compounds 2, 4 and 3 (each within the scatter of the next); then compound 1.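

In this assay, for the compounds shown here, replacing hydrogen with trifluoromethoxy (as a 1.2-fold lower number from compound 3 to compound 4 (0.08 log units; within the scatter)) gives the first reading at this aromatic carbon, para to a large group. A substituent of five heavy atoms fits here without a change beyond the scatter, whereas the earlier step concerned hydroxy at a different place. No measurement is available that would explain this result.

On these data alone, whether an amine or a carboxylic acid on this carbon would also leave the number within the scatter remains open. So does whether trifluoromethoxy would behave the same way on the core of compound 1, which lacks the hydroxy.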